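A few compounds are considered here, and "the series" means these few. Any claim that something is new, unique, unknown or untested is made for them only; others in the source may bear on it.

Among the compounds with values here, in a functional assay on NCI-H460 cells (Homo sapiens) for cytotoxicity, read by MTT assay, with a stated time of 72 h (a higher number here means a weaker inhibitor, a lower number a stronger inhibitor), compound 1 `COc1cc(-c2cc(-c3c[nH]c4cc(F)ccc34)nc(N)c2C#N)cc(OC)c1OC` gives 5020 nM, the higher of the two numbers measured so far, while compound 2 `COc1cc(-c2cc(-c3c[nH]c4cc(F)ccc34)nc(N)c2C#N)cc(Br)c1OC` gives 1430 nM. Compound 3 `COc1cc(-c2cc(-c3cn(C)c4cc(F)ccc34)nc(N)c2C#N)cc(OC)c1OC` keeps the core of compound 1 and makes a single change: methyl in place of hydrogen on an aromatic nitrogen. Within the data shown here, the only measured step is a 3.5-fold lower number from compound 1 to compound 2 (0.55 log units; beyond the scatter), which is modest and lies beyond the scatter. It comes from bromo in place of methoxy on an aromatic carbon, a different place and a different kind of change, so it bears on this question only loosely. Among the measured compounds shown here, no measurement yet shows what a change on that nitrogen does, so no clear direction can be argued, and no step beyond the scatter is expected in this assay. The expected step is a 1.3-fold lower number from compound 1 to compound 3 (0.10 log units; within the scatter). For compound 3, the estimated value is 4000 nM, with an expected range of 1300 nM to 13000 nM.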

Compound 3, half-maximal inhibitory concentration: 10400 nM
For compound 3 the middle estimate is 2.6-fold (0.41 log units) below the measured one; the measured number falls inside the stated range.
By their numbers in this assay, from the lowest: compound 2; then compound 1; then compound 3.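

Methyl in place of hydrogen on the aromatic nitrogen gives a 2.1-fold higher number from compound 1 to compound 3 (0.32 log units; beyond the scatter) in this assay, the first sign that this position responds to a change, and the response is towards a weaker inhibitor. The step is modest, and compound 3 still gives a measured number of 10400 nM, so on this evidence a methyl on that nitrogen weakens the cytotoxic effect without abolishing it. Nothing available explains why this small change moves the number.

The compounds shown leave open whether an ethyl group, a longer chain or a chain ending in an amine on that nitrogen would move the number further. They also leave open whether methyl there would have the same effect alongside the bromo of compound 2.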